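The compounds below may be only part of what the source reports. "The series", "measured", "known", "first", "only" and "open" are said of these compounds alone.

Measured so far:
compound 1, `Cc1c(C2CC2)nc2ccc(-n3ccc(OCc4ccc(C(F)(F)F)cc4)cc3=O)cn12`: 82 nM
compound 2, `Cc1c(CO)nc2ccc(-n3ccc(OCc4ccc(F)cc4)cc3=O)cn12`: > 1000 nM

Among the measured compounds shown here, compound 1, `Cc1c(C2CC2)nc2ccc(-n3ccc(OCc4ccc(C(F)(F)F)cc4)cc3=O)cn12`, is the only compound of the pair with a numeric value; in an assay on CHO cells for displacement of a labelled ligand from melanin-concentrating hormone receptor 1 (Rattus norvegicus), read by scintillation counting, with a stated time of 1 h (a lower number here means a stronger inhibitor, a higher number a weaker inhibitor), compound 1 gives 82 nM. Compound 2, `Cc1c(CO)nc2ccc(-n3ccc(OCc4ccc(F)cc4)cc3=O)cn12`, sits at a limit of the assay rather than a number, and in this assay compound 2 gives > 1000 nM; the other value shown is therefore the one that can anchor an estimate (the limit of > 1000 nM in this assay, at which 1 of the 2 values shown sits).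

The unmeasured compound 3, `Cc1c(C2CC2)nc2ccc(-n3ccc(OCc4csc(C(F)(F)F)c4)cc3=O)cn12`, differs from compound 1 in one place: 5-(trifluoromethyl)thiophen-3-yl in place of 4-(trifluoromethyl)phenyl on a saturated chain carbon bound to an oxygen on an aromatic ring. For the measured compounds named here, no step between measured compounds covers this kind of change, so the expectation rests on the value of compound 1 alone. The estimated step from compound 1 to compound 3 is a 1.3-fold higher number from compound 1 to compound 3 (0.13 log units; within the scatter), expected to lie within the usual scatter, with the trifluoromethyl group kept and the aromatic ring bearing it exchanged. Compound 3 is therefore expected to give about 110 nM in this assay, in a range from 40 nM to 350 nM.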

Compound 3, half-maximal inhibitory concentration: 15 nM
The estimate for compound 3 lay 7.3-fold (0.87 log units) above the measured number; measured number below the stated range.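

In this assay the exchange of 4-(trifluoromethyl)phenyl for 5-(trifluoromethyl)thiophen-3-yl gives a 5.5-fold lower number from compound 1 to compound 3 (0.74 log units; beyond the scatter) and so shows that the aromatic ring bearing the trifluoromethyl group can be changed without loss, with the five-membered ring giving the lower number in this pair. This is the only one-place comparison among the compounds shown, and it marks the place on a saturated chain carbon bound to an oxygen on an aromatic ring as one where a change of ring alone moves the number beyond the scatter. No measurement shown accounts for the gain.

Among the compounds shown here, for compound 2 the entry > 1000 nM is a limit of the assay and not a number, and compound 2 differs from compound 1 and compound 3 in more than one place, so no step to it can be read. Open, on these data alone, are whether a furan or pyridine ring bearing the trifluoromethyl group, or a chlorine atom in place of the trifluoromethyl group on the thiophene ring, would hold the gain, and whether it would persist with hydroxymethyl in place of cyclopropyl on the shared core.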